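A few compounds are considered here, and "the series" means these few. Any claim that something is new, unique, unknown or untested is made for them only; others in the source may bear on it.

Measured so far:
compound 1, `O[C@@H](c1ccccc1)[C@H]1CO[C@H](c2ccccc2)[C@@H](C/C=C/c2cccc(F)c2)C1`: 8380 nM
compound 2, `COc1ccc(/C=C/C[C@@H]2C[C@H]([C@H](O)c3ccc(OC)c(OC)c3)CO[C@H]2c2ccc(OC)c(OC)c2)cc1OC`: 28700 nM

Both were tested in a functional assay on HeLa cells (Homo sapiens) for cytotoxicity, read by WST assay, with a stated time of 48 h; a higher number here means a weaker inhibitor, a lower number a stronger inhibitor. Compound 1 gives the lowest of the two numbers; the nearest, compound 2, gives a higher number, and the gap between them is beyond the usual scatter of this kind of measurement. Compound 3, `O[C@@H](c1ccccc1)[C@H]1CO[C@H](c2ccccc2)[C@@H](C/C=C/C2CCCCC2)C1`, has not yet been measured in this assay. It differs from compound 1 in one place: cyclohexyl in place of 3-fluorophenyl on a double-bonded chain carbon bound to a double-bonded chain carbon. Among the measured compounds shown here, no measured pair here shows the effect of such a change, so there is nothing to anchor it to. Without such a reference, the expectation is for a small step, if any, with a lean toward a weaker inhibitor. Compound 3 is therefore expected to come out near 12000 nM, with a range from 4000 nM to 40000 nM. This estimate means an expected step of a 1.4-fold higher number from compound 1 to compound 3 (0.16 log units; within the scatter), which need not exceed the scatter.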

Compound 3, half-maximal inhibitory concentration: 6440 nM
Beside the measured number, compound 3's estimate is 1.9-fold (0.27 log units) above it, and the stated range covers the measured number.
By their numbers in this assay, from the lowest: compounds 3 and 1 (each within the scatter of the next); then compound 2.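

In this assay, putting cyclohexyl in place of 3-fluorophenyl on a double-bonded chain carbon bound to a double-bonded chain carbon gives a 1.3-fold lower number from compound 1 to compound 3 (0.11 log units; within the scatter), so the two compounds cannot be told apart. For this pair, then, neither an aromatic ring nor a fluorine in this place is needed for a number in this range, and a six-membered carbon ring of either kind serves equally well. Nothing measured here gives a reason for this result. Still open, from the compounds shown here alone, is whether this place accepts only a carbon ring of about this size, since a methyl group or a longer chain could read differently. An amine or a carboxylic acid here is equally uncharted, and the compounds shown give no guide to either.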